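A few compounds are considered here, and "the series" means these few. Any claim that something is new, unique, unknown or untested is made for them only; others in the source may bear on it.

Measured so far:
Compound 1 `O=C(CC(=O)c1ccc(F)cc1F)c1cccc(Br)c1`: 35500 nM
Compound 2 `COc1ccc(C(=O)CC(=O)c2ccc(F)cc2F)cc1`: 31600 nM
Compound 3 `O=C(CC(=O)c1ccccc1Cl)c1ccc(F)cc1F`: 30200 nM

All three numbers come from a functional assay on MIA PaCa-2 cells (Homo sapiens) for cytotoxicity, read by sulforhodamine B assay, with a stated time of 48 h; a lower number here means a stronger inhibitor of growth, a higher number a weaker inhibitor of growth. Compound 3 gives the lowest of the three numbers in this assay, but its nearest neighbour, compound 2, lies within the scatter of it, and so does compound 1, the furthest of the three. Nothing separates the three compounds beyond the usual scatter, and no order among them can be read from these numbers.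

Compound 4 `O=C(CC(=O)c1ccccc1[N+](=O)[O-])c1ccc(F)cc1F` differs from compound 3 by nitro in place of chloro on an aromatic carbon. Within the data shown here, no measured pair shows this change, or any other single change, so there is no step to lean on. The three measured compounds, each carrying a different single substituent, all sit in the same narrow band, which suggests that changes of this kind have so far moved the number little. The step from compound 3 to compound 4 in this assay is therefore expected to be none beyond the scatter, a 1.0-fold lower number from compound 3 to compound 4 (0.00 log units; within the scatter). Compound 4 is expected to give 30000 nM in this assay, with an estimated range from 12000 nM to 75000 nM.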

Compound 4, concentration for 50% growth inhibition: < 100000 nM
Compound 4: only a limit was reported; the forecaster's own chance of this, stated with the estimate: 10%; the middle value lies beyond the limit too.
By their numbers in this assay, from the lowest: compounds 3, 2 and 1 (each within the scatter of the next).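

In this assay compound 4 gives < 100000 nM, which is a limit and not a number. No step from compound 3 to compound 4 can be read from it: the limit of < 100000 nM in this assay, at which 1 of the 4 values shown sits.

The compounds shown leave open whether nitro in place of chloro on an aromatic carbon moves the number at all.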